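A few compounds are considered here, and "the series" means these few. Any claim that something is new, unique, unknown or untested is made for them only; others in the source may bear on it.

In an assay for inhibition of kynurenine 3-monooxygenase (Homo sapiens), read by mass spectrometry, with a stated time of 1 h (a higher number here means a weaker inhibitor, a lower number a stronger inhibitor), compound 1 `Cc1ccc([C@@H](C)Oc2cc3onc(CCC(=O)O)c3cc2Cl)nn1` gives 2 nM.
In this assay compound 2 `C[C@@H](Oc1cc2oc(=O)n(CCC(=O)O)c2cc1Cl)c1ccc(Cl)cn1` gives 3.16 nM.

Compound 1 has the lowest of the two numbers, but compound 2 sits within the usual scatter of it, so the two cannot be ranked. Compound 3 `C[C@@H](Oc1cc2onc(CCC(=O)O)c2cc1Cl)c1ccccn1` has not yet been measured. It differs from compound 1 in one place: pyridin-2-yl in place of 6-methylpyridazin-3-yl on a saturated chain carbon bound to an oxygen on an aromatic ring and a saturated chain carbon. For the measured compounds named here, no pair of measured compounds isolates this exchange, and compound 2 differs from compound 1 in more than one place, so its number cannot be used to read off the effect of the ring swap alone. The expectation for this step is a small one, either toward a somewhat higher number or none beyond the scatter. Compound 3 is therefore expected to give about 5 nM, with a range from 1.5 nM to 20 nM. This estimate means an expected step of a 2.5-fold higher number from compound 1 to compound 3 (0.40 log units; beyond the scatter).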

Compound 3, half-maximal inhibitory concentration: 5.01 nM
The estimate for compound 3 lay 1.0-fold (0.00 log units) below the measured number, within the range that was stated.
By their numbers in this assay, from the lowest: compounds 1, 2 and 3 (each within the scatter of the next, the first and the last beyond it).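

For the compounds shown here, the first direct reading at this position comes from this assay: placing pyridin-2-yl instead of 6-methylpyridazin-3-yl on the saturated chain carbon gives a 2.5-fold higher number from compound 1 to compound 3 (0.40 log units; beyond the scatter), a modest step. The core of compound 1 therefore keeps a strong inhibitor with either ring, though the position is not indifferent to the exchange. The ring that leaves has 2 hetero atoms and the ring that enters has 1 hetero atom, and the methyl group is lost in the same step. No evidence is available to explain the higher number.

These compounds leave open whether the ring nitrogen or the methyl group accounts for the step. A pyridazin-3-yl ring without the methyl group would separate the two, and a phenyl ring would show how this position responds to a ring with no nitrogen.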